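Swapping 4-methoxyphenyl for dibutylamino in compound 3

This account rests on a few compounds, and the source may have more. Where it says the series, first, only, none or still open, it means among the compounds named here.

In a functional assay on L1210 cells (Mus musculus) for inhibition (on this read-out higher numbers stand for weaker inhibition and lower numbers for stronger inhibition), compound 3 `COc1ccc([C@@H](O)COCCOC[C@@H](O)C#CCCCCCCC[C@@H]2CC(CC(C)=O)C(=O)O2)cc1` gives 32000 nM, the higher of the two values that are true numbers. Compound 2 `CCCCCCCCN(CCCCCCCC)C(O)(O)COCCOCC(O)(O)C#CCCCCCCC[C@@H]1CC(CC(C)=O)C(=O)O1` gives 3700 nM, lower by a margin beyond the scatter. Compound 1 `COc1ccc([C@H](O)COCCOC[C@H](O)C#CCCCCCCC[C@@H]2CC(CC(C)=O)C(=O)O2)cc1` reads > 10000 nM, which is a limit of the assay. Among the compounds with values here, the only measured step, a step that the limit leaves unreadable from compound 1 to compound 3, therefore offers no usable size. Compound 4 `CCCCN(CCCC)[C@@H](O)COCCOC[C@@H](O)C#CCCCCCCC[C@@H]1CC(CC(C)=O)C(=O)O1` differs from compound 3 by dibutylamino in place of 4-methoxyphenyl on a saturated chain carbon bound to an oxygen on a saturated carbon and a saturated chain carbon: dibutylamino in place of 4-methoxyphenyl on a saturated chain carbon. Within the data shown here, no measured step covers this change, so the expectation rests only on the number of compound 2 at 3700 nM. A moderate move towards stronger inhibition in this assay is expected, a 3.6-fold lower number from compound 3 to compound 4 (0.55 log units; beyond the scatter). For compound 4 the estimated value is 9000 nM, with an expected range of 2500 nM to 32000 nM.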

Compound 4, half-maximal inhibitory concentration: 2500 nM
Estimate against measurement, compound 4: 3.6-fold (0.56 log units) above; measured number inside the range.
By their numbers in this assay, from the lowest: compounds 4 and 2 (each within the scatter of the next); then compound 3.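

At this saturated chain carbon, the change now has a readable size in this assay: dibutylamino in place of 4-methoxyphenyl gives a 13-fold lower number from compound 3 to compound 4 (1.11 log units; beyond the scatter). The place therefore accepts a group with no ring, and for this pair that group gives the stronger inhibition. Nothing in the data gives a reason for this step.

As far as these compounds go, whether the step belongs to the nitrogen or to the two butyl chains remains open, as does how dimethylamino or piperidin-1-yl would read at this place. The effect of the opposite configuration on the dibutylamino compound is also unresolved.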